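Swapping the amide substituent on a tetrazole-bearing core

A few compounds are considered here, and "the series" means these few. Any claim that something is new, unique, unknown or untested is made for them only; others in the source may bear on it.

Measured compounds:
- Compound 1, `CCOc1nc2cccc(C(=O)N[C@H]3CC[C@H](C(=O)OC)CC3)c2n1Cc1ccc(-c2ccccc2-c2nnn[nH]2)cc1`: in an assay on isolated protein for inhibition of NEDD8-activating enzyme E1 regulatory subunit (Homo sapiens), read by Western blot, with stated times of 10 min and 30 min, tested at 25 uM (a higher number here means more inhibition at the concentration tested (going by the name of the read-out), a lower number less inhibition), compound 1 gives 28.6%.
- Compound 2, `CCOc1nc2cccc(C(=O)Nc3ccc(F)cc3)c2n1Cc1ccc(-c2ccccc2-c2nnn[nH]2)cc1`: in this assay compound 2 gives 45.3%.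

For the measured compounds named here, compound 2 stands highest of the two measured numbers; its nearest neighbour is compound 1, and the one recorded step runs a number 16.7 percentage points higher from compound 1 to compound 2 (beyond the scatter). Compound 3, `CCOc1nc2cccc(C(=O)NCc3ccco3)c2n1Cc1ccc(-c2ccccc2-c2nnn[nH]2)cc1`, keeps the shared core and changes only the group on the amide-type nitrogen: (furan-2-yl)methyl in place of 4-fluorophenyl on an amide-type nitrogen. Going by the values given here, the single measured step replaced a saturated ring carrying an ester with 4-fluorophenyl, so it does not cover the exchange of one aromatic group for a (furan-2-yl)methyl chain; no measured pair bears directly on this change. Among the compounds with values here, with only that indirect guide, a modest fall or no step beyond the scatter seems the likeliest outcome, and compound 3 is expected to show a step of a number 10.3 percentage points lower from compound 2 to compound 3 (beyond the scatter). Compound 3 is therefore estimated at 35%, within a range from 15% to 55%.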

Compound 3, a percentage reported as inhibition, at one concentration (the size of the read-out at that concentration, not a potency): 37.5%
Beside the measured number, compound 3's estimate is 2.5 percentage points below it, within the range that was stated.
By their numbers in this assay, from the lowest: compounds 1, 3 and 2 (each within the scatter of the next, the first and the last beyond it).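

In this assay the (furan-2-yl)methyl group on the amide-type nitrogen cannot be told apart from 4-fluorophenyl, with a number 7.8 percentage points lower from compound 2 to compound 3 (within the scatter) and it also cannot be told apart from 4-(methoxycarbonyl)cyclohexyl, with a number 8.9 percentage points higher from compound 1 to compound 3 (within the scatter) even though those two groups differ from each other beyond the scatter. This position therefore accepts a five-membered aromatic ring with one hetero atom while the number stays within the scatter of both earlier compounds, so the third group adds no clear place in the order. Nothing measured here explains these numbers.

Still open, as far as these compounds go, is whether phenylmethyl on this nitrogen would match compound 3, which would help separate the effect of the ring from that of the connecting carbon. A carboxylic acid in place of the methyl ester of compound 1, or an amine at the end of a longer chain on this nitrogen, also remains to be placed against these three compounds.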